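The source may hold more compounds than are shown below. What is called first, only, known or untested is meant among the compounds shown, and "the series" means these compounds.

Measured in a functional assay on thoracic aorta for antagonist activity at thromboxane A2 receptor (Rattus norvegicus); a higher number here means a weaker inhibitor, a lower number a stronger inhibitor:
Compound 1 `CC(C)c1ccc2c(CNC(=O)CNS(=O)(=O)c3ccccc3)cc(C(=O)O)c-2cc1`: only a limit of the assay, > 100000 nM
Compound 2 `CC(C)c1ccc2c(CNC(=O)CNS(=O)(=O)c3ccc(Cl)cc3)cc(C(=O)O)c-2cc1`: only a limit of the assay, > 100000 nM
Compound 3 `CC(C)c1ccc2c(CCCCCS(=O)(=O)Nc3ccccc3)cc(S(=O)(=O)O)c-2cc1`: 1400 nM

Compound 1 and compound 2 share a core and differ by chloro in place of hydrogen on an aromatic carbon; the step that the two limits leave unreadable from compound 1 to compound 2 cannot be sized, since both values sit at the limit of > 100000 nM in this assay, at which 2 of the 3 values shown sit. Compound 3 has a different core, and the difference between the two cores is not broken down here. The unmeasured compound 4 `CC(C)c1ccc2c(CCCCCS(=O)(=O)Nc3ccc(Cl)cc3)cc(S(=O)(=O)O)c-2cc1` carries the same change relative to compound 3, namely (chloro in place of hydrogen on an aromatic carbon). Because the step from compound 1 to compound 2 is hidden by the limit of > 100000 nM in this assay, at which 2 of the 3 values shown sit, nothing measured sets the size of this change, so compound 4 is expected to stay close to compound 3, with the estimated step of a 1.6-fold lower number from compound 3 to compound 4 (0.19 log units; within the scatter) in this assay. The estimate for compound 4 is 900 nM, spanning 250 nM to 3500 nM.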

Compound 4, half-maximal inhibitory concentration: 860 nM
Beside the measured number, compound 4's estimate is 1.0-fold (0.02 log units) above it; the range from low to high includes it.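

In this assay, chloro in place of hydrogen on an aromatic carbon of the core of compound 3 gives a 1.6-fold lower number from compound 3 to compound 4 (0.21 log units; within the scatter), so on this core the change shows no effect beyond the scatter. This is one pair on one core, and it does not show that the change behaves alike on another core. The step on the core of compound 1 cannot be read, which leaves no second size to set against this one: the limit of > 100000 nM in this assay, at which 2 of the 4 values shown sit.

The compounds shown leave open whether a bromo or methoxy group in place of the chloro would give a step beyond the scatter. They also leave open what a longer chain would do on the core of compound 3.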